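The source may hold more compounds than are shown below. What is called first, only, known or untested is meant among the compounds shown, and "the series" means these compounds.

Among the measured compounds shown here, in a functional assay on SK-BR-3 cells (Homo sapiens) for antiproliferative activity, with a stated time of 48 h (on this read-out higher numbers stand for an effect only at larger amounts of compound and lower numbers for an effect already at smaller amounts), three compounds have numbers so far: compound 1 `Nc1ccc(NC(=O)CCCCCCC(=O)NO)cc1` gives 8500 nM, compound 2 `O=C(CCCCCCC(=O)Nc1ccc(C(F)(F)F)cc1)NO` gives 2200 nM and compound 3 `O=C(CCCCCCC(=O)Nc1ccccc1Br)NO` gives 17500 nM. Compound 2 holds the lowest number of the three, and its distance to each of the other two lies beyond the scatter. The next compound, compound 4 `O=C(CCCCCCC(=O)Nc1ccc(I)cc1)NO`, differs from compound 2 in one place: iodo in place of trifluoromethyl on an aromatic carbon. This is iodo in place of trifluoromethyl on an aromatic carbon, para to a large group. For the measured compounds named here, only one measured step concerns that carbon, a 3.9-fold lower number from compound 1 to compound 2 (0.59 log units; beyond the scatter), and it is modest in size. Going by the values given here, no measured compound carries iodo, and no single-place step links compound 3 to compound 2, so compound 3 offers no direct guide. Among the compounds with values here, with only that one modest step to go on, a small change is expected in this assay. The expected step, a 1.4-fold higher number from compound 2 to compound 4 (0.13 log units; within the scatter), is estimated to stay within the scatter, although a shift of modest size in either direction remains possible. Compound 4 is estimated at 3000 nM, with an expected range from 1000 nM to 8000 nM.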

Compound 4, half-maximal effective concentration: 1100 nM
Compound 4: the middle estimate sits 2.7-fold (0.44 log units) above what was measured; the range from low to high includes it.
By their numbers in this assay, from the lowest: compounds 4 and 2 (each within the scatter of the next); then compound 1; then compound 3.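

In this assay, trifluoromethyl and iodo on this aromatic carbon cannot be told apart: replacing the one with the other gives a 2.0-fold lower number from compound 2 to compound 4 (0.30 log units; within the scatter), even though the group leaving has four heavy atoms and the group entering has one. Amino on the same carbon now stands apart from two different groups rather than one, with iodo giving a 7.7-fold lower number from compound 1 to compound 4 (0.89 log units; beyond the scatter) and trifluoromethyl giving a 3.9-fold lower number from compound 1 to compound 2 (0.59 log units; beyond the scatter), so the earlier step no longer rests on a single replacement. Nothing measured here bears on why the two groups sit so close together or why amino stands apart.

From the compounds shown here alone, whether other groups on this carbon, such as chloro, methoxy or a carboxylic acid, would fall with iodo and trifluoromethyl or with amino remains open. Compound 3 carries bromo at a different place and is linked to the others by no single-place step, so the compounds shown do not separate the effect of the group from the effect of its place on the ring, and they leave open whether a longer chain would preserve the pattern.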